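Fluoro to Methyl on the Aryl Group: Aorta Inhibition

This account rests on a few compounds, and the source may have more. Where it says the series, first, only, none or still open, it means among the compounds named here.

Compound 1, `CCOC(=O)c1c(-c2ccc(C)cc2)cc(-c2ccccc2)nc1N1CCCCC1`, gives 175000 nM in a functional assay on thoracic aorta (strain Wistar) with Aorta (Rattus norvegicus) as the target, with a stated time of 2 h; on this read-out lower numbers stand for stronger inhibition and higher numbers for weaker inhibition.
Compound 2, `CCOC(=O)c1c(-c2ccc(C)cc2)cc(-c2ccccc2)nc1Nc1ccc(Cl)cc1`, gives 266000 nM in this assay.
Compound 3, `CCOC(=O)c1c(-c2ccc(F)cc2)cc(-c2ccccc2)nc1Nc1ccc(OC)cc1`, gives 254000 nM in this assay.

All three numbers are weak and close together. Compound 3 stands second highest of the three; its nearest neighbour is compound 2, whose number lies within the scatter of it, and compound 1, the furthest, is also within the scatter. Among the compounds with values here, the only step between compounds that differ in one place is a 1.5-fold higher number from compound 1 to compound 2 (0.18 log units; within the scatter), which changes the group on the ring carbon bearing the amine and not the aryl substituent.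

Compound 4, `CCOC(=O)c1c(-c2ccc(C)cc2)cc(-c2ccccc2)nc1Nc1ccc(OC)cc1`, differs from compound 3 by methyl in place of fluoro on an aromatic carbon. Within the data shown here, no measured step isolates this change: compound 2 and compound 3 differ in two places at once, and their values sit within the scatter of each other. With the three measured numbers spread over a range that is itself within the scatter, the step from compound 3 to compound 4 in this assay is expected to be small, a 1.1-fold lower number from compound 3 to compound 4 (0.02 log units; within the scatter), with no clear direction. Compound 4 is therefore estimated at 240000 nM, within 110000 nM to 520000 nM.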

Compound 4, half-maximal inhibitory concentration: 233000 nM
Beside the measured number, compound 4's estimate is 1.0-fold (0.01 log units) above it, and the stated range covers the measured number.
By their numbers in this assay, from the lowest: compounds 1, 4, 3 and 2 (each within the scatter of the next).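

The change of 4-fluorophenyl to 4-methylphenyl, on an aromatic carbon para to a large group, can now be read directly in this assay, and it gives a 1.1-fold lower number from compound 3 to compound 4 (0.04 log units; within the scatter), so at this position the two groups cannot be told apart in this read-out. The amine side gives the same picture: methoxy in place of chloro gives a 1.1-fold lower number from compound 2 to compound 4 (0.06 log units; within the scatter), and (4-methoxyphenyl)amino in place of piperidin-1-yl gives a 1.3-fold higher number from compound 1 to compound 4 (0.12 log units; within the scatter), so neither of these changes separates its pair of compounds any more than the earlier step did. Nothing available explains why these numbers stay so close together.

What the compounds shown leave open is whether any group at this position can move the number beyond the scatter, for instance an amine or a carboxylic acid on the aromatic carbon that carries methyl in compound 4. On these data alone, it is equally open whether a longer chain there, or a hydroxyl group in place of methoxy on the amine side, would separate itself from compound 4 in this assay.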